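This account rests on a few compounds, and the source may have more. Where it says the series, first, only, none or still open, it means among the compounds named here.

Measured compounds in the series:
compound 1 `Oc1ccccc1/C=N/c1ccc(OCc2ccccc2)cc1` gives 25100 nM in an assay on isolated protein for inhibition of Amine oxidase [flavin-containing] B (Homo sapiens), read by fluorescence and Amplex Red, with stated times of 15 min and 20 min; a lower number here means a stronger inhibitor, a higher number a weaker inhibitor.
compound 2 `Oc1ccc(/C=N/c2ccc(OCc3ccccc3)cc2)c(O)c1O` gives 1730 nM in this assay.
compound 3 `COc1ccc(/C=N/c2ccc(OCc3ccccc3)cc2)c(O)c1` gives 23600 nM in this assay.

Compound 1 stands highest of the three numbers in this assay. Compound 3 is nearest to it, and the two values lie within the scatter of each other; compound 2 is furthest, its value a full step beyond the scatter from that of compound 1.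

The next compound to be measured is compound 4 `Cc1ccc(O)c(/C=N/c2ccc(OCc3ccccc3)cc2)c1`. Relative to compound 1 the change is methyl in place of hydrogen on an aromatic carbon.

For the measured compounds named here, one measured step bears on this change: a 1.1-fold lower number from compound 1 to compound 3 (0.03 log units; within the scatter), a substitution on the same ring of the shared core that did not move the number beyond the scatter. Going by the values given here, no measured pair shows a methyl at this place, so the only guide is that single step, and it gives no reason to expect a move beyond the scatter in this assay.

The estimate for compound 4 is therefore 22000 nM, with a range from 9000 nM to 55000 nM, which means an expected step of a 1.1-fold lower number from compound 1 to compound 4 (0.06 log units; within the scatter).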

Compound 4, half-maximal inhibitory concentration: 24600 nM
Estimate against measurement, compound 4: 1.1-fold (0.05 log units) below, and the stated range covers the measured number.
By their numbers in this assay, from the lowest: compound 2; then compounds 3, 4 and 1 (each within the scatter of the next).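

In this assay, for the compounds shown here, the new compound gives the first reading for an added carbon group at this place, on an aromatic carbon para to a hydroxy group and meta to a large group, and the result is (a 1.0-fold lower number from compound 1 to compound 4 (0.01 log units; within the scatter)). The earlier step (a 1.1-fold lower number from compound 1 to compound 3 (0.03 log units; within the scatter)) concerned methoxy at a different carbon of the ring, so this position now has its own reading, and 2-hydroxyphenyl to 2-hydroxy-5-methylphenyl leaves the number within the scatter. Nothing available explains this result.

Still open, going by these compounds, is whether a group other than methyl at this carbon, such as an amine, a carboxylic acid or a longer chain, would move the number beyond the scatter. Also open, on these data alone, is how methyl would read on the remaining carbons of this ring.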